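The source may report more compounds than this note shows. Statements on the series, on what has been measured and on what is new or still open speak of the compounds shown alone.

Measured compounds:
compound 1, `O=C(/C(=C\c1ccc([N+](=O)[O-])c(O)c1)SCc1ccc(Br)cc1)c1ccc(C(F)(F)F)cc1`: 1000 nM
compound 2, `O=C(/C(=C\c1ccc(O)c([N+](=O)[O-])c1)SCc1ccc(Br)cc1)c1ccc(C(F)(F)F)cc1`: 10000 nM
compound 3, `O=C(/C(=C\c1ccc([N+](=O)[O-])c(O)c1)Sc1c(F)c(F)c(F)c(F)c1F)c1ccc(Br)cc1`: 10000 nM

In a functional assay on DU-145 cells (Homo sapiens) for inhibition, read by trypan blue exclusion, with a stated time of 96 h (on this read-out lower numbers stand for stronger inhibition of growth and higher numbers for weaker inhibition of growth), compound 1 gives 1000 nM, compound 2 gives 10000 nM and compound 3 gives 10000 nM. Compound 2 differs from compound 1 in one place: 4-hydroxy-3-nitrophenyl in place of 3-hydroxy-4-nitrophenyl on a double-bonded chain carbon bound to a double-bonded chain carbon. That change made a step of a 10-fold higher number from compound 1 to compound 2 (1.00 log units; beyond the scatter). Compound 3 is built on a different core from compound 1; the difference between the two cores is not broken down here. In this assay compound 3 and compound 2 stand level at the digits given, and both lie a step beyond the scatter away from compound 1.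

Compound 4, `O=C(/C(=C\c1ccc(O)c([N+](=O)[O-])c1)Sc1c(F)c(F)c(F)c(F)c1F)c1ccc(Br)cc1`, is not yet measured. It differs from compound 3 in one place: 4-hydroxy-3-nitrophenyl in place of 3-hydroxy-4-nitrophenyl on a double-bonded chain carbon bound to a double-bonded chain carbon. This is the same change as was made from compound 1 to compound 2, and it occurs twice among the compounds shown. The step of a 10-fold higher number from compound 1 to compound 2 (1.00 log units; beyond the scatter) lay beyond the scatter. On that single prior instance, seen on a different core, a step in the same direction but of uncertain size is expected for compound 4, a 3.0-fold higher number from compound 3 to compound 4 (0.48 log units; beyond the scatter). Since compound 3 already sits at the high end of the measured range, the expected range is kept wide. Compound 4 is estimated at 30000 nM in this assay, between 10000 nM and 100000 nM.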

Compound 4, concentration for 50% growth inhibition: 10000 nM
For compound 4 the middle estimate is 3.0-fold (0.48 log units) above the measured one; measured number inside the range.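

In this assay, putting 4-hydroxy-3-nitrophenyl in place of 3-hydroxy-4-nitrophenyl gave no change at the digits printed from compound 3 to compound 4 (within the scatter), so the step seen on the core of compound 1 did not carry over to the core of compound 3, and the two instances differ: the same change on two cores in this assay, a 10-fold higher number (1.00 log units; beyond the scatter) from compound 1 to compound 2 and no change at the digits printed (within the scatter) from compound 3 to compound 4, 10-fold (1.00 log units) apart, beyond the scatter of two such steps. Across these two cores, the outcome of this change depends on the core that carries it, and a step read on one core is no safe guide to the other. This does not show which feature of the cores is responsible, as they differ in more than one place, and two instances give no rule for any further core.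

Left open is which of the parts separating the two cores governs the step, and whether a compound with only one of those parts exchanged would follow compound 2 or compound 4. Equally open, on these data alone, is how a carboxylic acid or an amine in place of the nitro group would behave on either core.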